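The source may report more compounds than this note shows. Statements on the series, on what has been measured and on what is new or still open speak of the compounds shown alone.

Compound 1 (`Cc1cc(NC(=O)Nc2cccc(F)c2)c2ccccc2n1`) and compound 2 (`Cc1cc(NC(=O)Nc2ccccc2F)c2ccccc2n1`) share one core and differ only in where a fluoro group sits. For the measured compounds named here, in a physicochemical assay for solubility, at pH 7.4 (on this read-out lower numbers stand for lower solubility and higher numbers for higher solubility), compound 1 gives 100 nM, while compound 2 gives 3800 nM, the higher of the two numbers so far.

Compound 3 (`Cc1cc(NC(=O)Nc2cc(F)ccc2F)c2ccccc2n1`) keeps all of compound 2 and adds one group: fluoro in place of hydrogen on an aromatic carbon. This is fluoro in place of hydrogen on an aromatic carbon, meta to a large group and para to a fluoro group.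

Going by the values given here, only one measured step bears on this change: a 38-fold higher number from compound 1 to compound 2 (1.58 log units; beyond the scatter). It is a large step, but it moves a fluoro group rather than adding one, so it is only a loose guide. Still, the new fluoro of compound 3 stands meta to a large group, as the fluoro of compound 1 does, and compound 1 shows the low value of 100 nM. A lower number in this assay is therefore expected. Compound 3 still holds the fluoro of compound 2, so only part of that large step is expected to return.

The expected change is a 3.8-fold lower number from compound 2 to compound 3 (0.58 log units; beyond the scatter). For compound 3 the estimated value is 1000 nM, with an expected range from 200 nM to 4500 nM.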

Compound 3, solubility: 500 nM
Compound 3: middle estimate off by 2.0-fold (0.30 log units), on the high side, within the range that was stated.
By their numbers in this assay, from the lowest: compound 1; then compound 3; then compound 2.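

Adding one fluoro to this ring does not move the number in a single direction in this assay: with the new fluoro meta to a large group and para to a fluoro group, the data show a 7.6-fold lower number from compound 2 to compound 3 (0.88 log units; beyond the scatter) and, for the other single-fluoro parent, a 5.0-fold higher number from compound 1 to compound 3 (0.70 log units; beyond the scatter). Across these three compounds, then, the direction of the step depends on which fluoro the ring already carries, and the compound with both fluoro groups falls between the two compounds with one. No measurement shown here explains why the number moves in either direction.

A fluoro is the only group shown at this carbon, so it remains open whether a chloro, a methoxy or an amine in the same place would give a step in the same direction or of a similar size. These three compounds also leave open whether the opposite directions seen here would recur on a ring carrying a group other than fluoro, or with a different group on the shared core.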